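Benzyl ether halogen pattern in the thiourea series

A few compounds are considered here, and "the series" means these few. Any claim that something is new, unique, unknown or untested is made for them only; others in the source may bear on it.

Compound 1 `Cc1ccc(NC(=S)NC(=O)c2ccc(OCc3cccc(Cl)c3)cc2)cc1-c1nc2ccccc2[nH]1` carries a 3-chlorobenzyl ether on the shared core. In a functional assay on SW-620 cells (Homo sapiens) for inhibition, read by MTT assay, with a stated time of 48 h (on this read-out higher numbers stand for weaker inhibition and lower numbers for stronger inhibition), compound 1 reaches only the assay limit, > 100000 nM, and gives no number. Compound 2 `Cc1ccc(NC(=S)NC(=O)c2ccc(OCc3cccc(F)c3)cc2)cc1-c1nc2ccccc2[nH]1` likewise stops at the limit > 100000 nM in this assay. Compound 3 `Cc1ccc(NC(=S)NC(=O)c2ccc(OCc3ccc(Cl)c(Cl)c3)cc2)cc1-c1nc2ccccc2[nH]1` gives a readable 30700 nM in this assay, so the steps of an at least 3.2-fold lower number from compound 1 to compound 3 (0.51 log units; beyond the scatter) and an at least 3.2-fold lower number from compound 2 to compound 3 (0.51 log units; beyond the scatter) both leave the limit. The step that the two limits leave unreadable from compound 1 to compound 2 cannot be read because both values sit at the limit of > 100000 nM in this assay, at which 2 of the 3 values shown sit. Compound 4 `Cc1ccc(NC(=S)NC(=O)c2ccc(OCc3ccc(Cl)cc3Cl)cc2)cc1-c1nc2ccccc2[nH]1` has not been measured; its change from compound 1 is 2,4-dichlorophenyl in place of 3-chlorophenyl on a saturated chain carbon bound to an oxygen on an aromatic ring. Compound 3, with its dichlorophenyl, moved off the limit by an at least 3.2-fold lower number from compound 1 to compound 3 (0.51 log units; beyond the scatter), and a step of comparable size is expected for compound 4, an at least 2.5-fold lower number from compound 1 to compound 4 (0.39 log units; beyond the scatter). Compound 4 is therefore estimated at 40000 nM, between 12000 nM and 100000 nM.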

Compound 4, half-maximal inhibitory concentration: 57200 nM
For compound 4 the middle estimate is 1.4-fold (0.16 log units) below the measured one, and the stated range covers the measured number.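

In this assay, a second dichloro pattern also gives a readable number, so leaving the limit is not confined to the 3,4-dichlorophenyl group of compound 3. The change of chlorine pattern gives a 1.9-fold higher number from compound 3 to compound 4 (0.27 log units; within the scatter), so the two patterns are not told apart here. The steps from the two limit compounds are only floors, an at least 1.7-fold lower number from compound 1 to compound 4 (0.24 log units; that floor lies within the scatter) and an at least 1.7-fold lower number from compound 2 to compound 4 (0.24 log units; that floor lies within the scatter), and neither separates compound 4 from them: the limit of > 100000 nM in this assay, at which 2 of the 4 values shown sit.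

Still open, on these data alone, is whether an amine or a carboxylic acid on this benzyl ring, or a longer chain at the ether, would read differently from the two dichloro compounds.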